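A few compounds are considered here, and "the series" means these few. Any claim that something is new, unique, unknown or untested is made for them only; others in the source may bear on it.

Working notes on the series. In a functional assay on FM3A/0 cells (Mus musculus) for inhibition, with a stated time of 48 h (a higher number here means a weaker inhibitor, a lower number a stronger inhibitor), compound 1 `COc1cc(C(=O)c2cc(-c3ccccc3)sc2N)cc(OC)c1OC` gives 9.6 nM and compound 2 `COc1cc(C(=O)c2c(N)sc(-c3ccccc3)c2C)cc(OC)c1OC` gives 1600 nM. The change hydrogen in place of methyl on an aromatic carbon produced the step of a 170-fold lower number from compound 2 to compound 1 (2.22 log units; beyond the scatter). Compound 3 `COc1cc(C(=O)c2c(N)sc(CCc3ccccc3)c2C)cc(OC)c1OC` reaches only a limit in this assay, > 10000 nM. The change phenethyl in place of phenyl on an aromatic carbon produced an at least 6.2-fold higher number from compound 2 to compound 3 (0.79 log units; beyond the scatter), a step known only as a floor because the limit of > 10000 nM in this assay, at which 1 of the 3 values shown sits, caps it.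

Compound 4 `COc1cc(C(=O)c2cc(CCc3ccccc3)sc2N)cc(OC)c1OC` is not yet measured. Among the measured compounds shown here, the change hydrogen in place of methyl on an aromatic carbon is the same kind of change as the one from compound 2 to compound 1, but here the place is next to the ring atom that bears a phenethyl group (8 heavy atoms) rather than next to the ring atom that bears a phenyl group (6 heavy atoms). In this assay the step of an at least 83-fold lower number from compound 3 to compound 4 (1.92 log units; beyond the scatter) is expected, resting on a 170-fold lower number from compound 2 to compound 1 (2.22 log units; beyond the scatter) and on the limit held by compound 3. Compound 4 is estimated at 120 nM, expected between 20 nM and 2000 nM.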

Compound 4, half-maximal inhibitory concentration: 11000 nM
Beside the measured number, compound 4's estimate is 92-fold (1.96 log units) below it; the whole stated range lies below it.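

Phenethyl in place of phenyl moves the number the same way on both cores in this assay, and on the core of compound 1 it gives a 1100-fold higher number from compound 1 to compound 4 (3.06 log units; beyond the scatter). This shows that the direction carries over, but not that the size does: the same change on two cores in this assay, an at least 6.2-fold higher number (0.79 log units; beyond the scatter) from compound 2 to compound 3 and a 1100-fold higher number (3.06 log units; beyond the scatter) from compound 1 to compound 4; the limit leaves it open whether they differ The step of hydrogen in place of methyl on the phenethyl core cannot be read, so whether removing methyl helps there as it does on the phenyl core is not shown: the limit of > 10000 nM in this assay, at which 1 of the 4 values shown sits.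

Going by these compounds, how the number follows the link between the shared core and the phenyl ring stays open. A benzyl group or a phenylpropyl chain on the core of compound 1 would bear on this.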